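A few compounds are considered here, and "the series" means these few. Any claim that something is new, unique, unknown or untested is made for them only; others in the source may bear on it.

Measured so far in a functional assay on the whole organism with Rattus norvegicus as the target; on this read-out higher numbers stand for an effect only at larger amounts of compound and lower numbers for an effect already at smaller amounts:
compound 1, `COc1cc(N)c(Cl)cc1C(=O)NCC1CCCN1Cc1ccccc1`: 1.1 mg/kg
compound 2, `CNc1cc(OC)c(C(=O)NCC2CCCN2Cc2ccccc2)cc1Cl`: 0.94 mg/kg
compound 3, `CNc1cc(OC)c(C(=O)NC2CCN(Cc3ccccc3)C2)cc1Cl`: 0.016 mg/kg

Compound 1 and compound 2 share one core. Compound 3 is built from the same atoms as compound 1, joined differently, and the difference between the two cores is not broken down here. Compound 3 stands lowest of the three numbers in this assay; compound 2 is nearest and compound 1 furthest, both steps beyond the scatter.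

Compound 2 differs from compound 1 by methyl in place of hydrogen on a nitrogen on an aromatic ring. On this assay this step reads a 1.2-fold lower number from compound 1 to compound 2 (0.07 log units; within the scatter).

Compound 4, `COc1cc(N(C)C)c(Cl)cc1C(=O)NC1CCN(Cc2ccccc2)C1`, is not yet measured. It differs from compound 3 by methyl in place of hydrogen on a nitrogen on an aromatic ring. Among the measured compounds shown here, this is the same kind of change as the one between compound 1 and compound 2, not the same: in compound 1 the other neighbour of the nitrogen is an aromatic carbon only, whereas in compound 3 the other neighbours are an aromatic carbon and a saturated chain carbon, and the core is a different one. For the measured compounds named here, only one such step is measured and it lies within the scatter. On that single precedent the step is expected to be about a 1.3-fold higher number from compound 3 to compound 4 (0.10 log units; within the scatter). Going by the values given here, compound 4 is therefore estimated at 0.02 mg/kg in this assay, with a range from 0.007 mg/kg to 0.06 mg/kg because the sole measured precedent is a 1.2-fold lower number from compound 1 to compound 2 (0.07 log units; within the scatter), while the differing surroundings and the other core leave the transfer uncertain.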

Compound 4, dose for half-maximal effect: 0.12 mg/kg
Compound 4: middle estimate off by 6.0-fold (0.78 log units), on the low side; the whole stated range lies below it.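

In this assay, adding the second methyl to the aromatic nitrogen gives a 7.5-fold higher number from compound 3 to compound 4 (0.88 log units; beyond the scatter), and this does not match the earlier step of the same kind: the same change on two cores in this assay, a 1.2-fold lower number (0.07 log units; within the scatter) from compound 1 to compound 2 and a 7.5-fold higher number (0.88 log units; beyond the scatter) from compound 3 to compound 4, 8.8-fold (0.94 log units) apart, beyond the scatter of two such steps

The size of this change therefore does not carry from the core of compound 1 to the core of compound 3; a step within the scatter on one core gave no safe guide to the step on the other, and any later transfer between these cores needs a wide allowance. What this does not show is which difference is responsible, since the two pairs differ both in the core and in the surroundings of the nitrogen, with methylamino going to dimethylamino only in the second pair, and two pairs cannot separate these factors or support a rule for the series.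

The compounds shown leave open how the dimethylamino group reads on the core of compound 1, which would put the same group on both cores and so separate the core from the surroundings of the nitrogen. They also leave open whether a longer chain on that nitrogen, such as ethyl in place of methyl on the methylamino group of compound 3, follows the same direction.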